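The compounds below may be only part of what the source reports. "The series", "measured", "known", "first", "only" and "open" are said of these compounds alone.

Measured so far:
Compound 1 `FC(F)(F)c1ccc(-c2csc(N3N=C(c4ccc(N5CCCCC5)cc4)CC3c3ccc(Cl)cc3)n2)cc1`: in a functional assay on A-375 cells (Homo sapiens) for antiproliferative activity, read by MTT assay, with a stated time of 72 h (a lower number here means a stronger inhibitor, a higher number a weaker inhibitor), compound 1 gives 64200 nM.
Compound 2 `Cc1ccc(-c2csc(N3N=C(c4ccc(N5CCCCC5)cc4)CC3c3ccc(Cl)cc3)n2)cc1`: in this assay compound 2 gives only a limit, > 100000 nM.

Compound 2 therefore stands at the weak end of what this assay can report; the limit of > 100000 nM in this assay, at which 1 of the 2 values shown sits, is known for it, not a number. Among the compounds with values here, the single measured step, an at least 1.5-fold higher number from compound 1 to compound 2 (0.19 log units; that floor lies within the scatter), exchanges one group at the same position that changes next, and it moved little. Compound 3 `COc1ccc(-c2csc(N3N=C(c4ccc(N5CCCCC5)cc4)CC3c3ccc(Cl)cc3)n2)cc1` differs from compound 2 by methoxy in place of methyl on an aromatic carbon. Judging only from that step, no shift beyond the scatter is expected in this assay. Compound 3 is estimated at 100000 nM, between 45000 nM and 250000 nM, an expected step of a number no higher from compound 2 to compound 3 (the limit leaves the size open), most likely again reported as a limit.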

Compound 3, half-maximal inhibitory concentration: > 100000 nM
Compound 3: only a limit was reported; the forecaster's own chance of this, stated with the estimate: 60%; the middle value lies on the limit itself.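

With methoxy as with methyl, this aromatic carbon gives no number that can be read, and the step between compound 2 and compound 3 cannot be read because both values are limits: the limit of > 100000 nM in this assay, at which 2 of the 3 values shown sit.

Methoxy in place of trifluoromethyl gives an at least 1.5-fold higher number from compound 1 to compound 3 (0.19 log units; that floor lies within the scatter), so this change cannot be separated from the scatter, and among these three compounds only compound 1, with its trifluoromethyl group, has a measured value.

Still open, going by these compounds, is whether an amine, a carboxylic acid or a longer chain on this aromatic carbon would give a measured number in this assay, and whether that number would clearly improve on compound 1, which gives 64200 nM.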